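Swapping Fluoro for Isopropoxy and What the Cells Tolerate

A few compounds are considered here, and "the series" means these few. Any claim that something is new, unique, unknown or untested is made for them only; others in the source may bear on it.

Three compounds sharing one core were examined in an ADME assay on HEK293 cells (Homo sapiens) for cytotoxicity, read by MTT assay, with a stated time of 72 h; a lower number here means a stronger inhibitor, a higher number a weaker inhibitor. Compound 2 `COc1ccc(C2=C(c3cc(OC)c(OC)c(OC)c3)C(=O)C(OC(C)=O)C2)cc1F` carries a fluoro group on the aromatic ring and an acetyl on the oxygen of the saturated carbon, and in this assay compound 2 gives 59 ug/mL. Compound 1 `COc1ccc(C2=C(c3cc(OC)c(OC)c(OC)c3)C(=O)C(OC(C)=O)C2)cc1OC(C)C` gives > 100 ug/mL, which is a limit of the assay and not a number. Compound 3 `COc1ccc(C2=C(c3cc(OC)c(OC)c(OC)c3)C(=O)C(O)C2)cc1F` likewise gives > 100 ug/mL, again only a limit.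

The change from compound 2 to compound 1 is isopropoxy in place of fluoro on an aromatic carbon, and it made an at least 1.6-fold higher number from compound 2 to compound 1 (0.22 log units; that floor lies within the scatter). The change from compound 2 to compound 3 is hydrogen in place of acetyl on an oxygen on a saturated carbon, and it made an at least 1.6-fold higher number from compound 2 to compound 3 (0.22 log units; that floor lies within the scatter). Both steps end at the limit of > 100 ug/mL in this assay, at which 2 of the 3 values shown sit, so neither size can be fixed beyond its floor.

Compound 4 `COc1ccc(C2=C(c3cc(OC)c(OC)c(OC)c3)C(=O)C(O)C2)cc1OC(C)C` has not yet been measured. It differs from compound 3 by isopropoxy in place of fluoro on an aromatic carbon, the same change that led from compound 2 to compound 1, and the place is described in the same words in both cases. Since compound 3 already stands at the limit, and the same change did not lower the number when it took compound 2 to compound 1, compound 4 is expected to sit at or beyond that limit as well. The step from compound 3 to compound 4 is estimated as a step that the limit leaves unreadable from compound 3 to compound 4. Compound 4 is thus estimated at 150 ug/mL, between 100 ug/mL and 300 ug/mL.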

Compound 4, half-maximal inhibitory concentration: > 100 ug/mL
Compound 4: a limit, no number; the forecaster's own chance of this, stated with the estimate: 85%; the middle value lies beyond the limit too.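

Compound 4 gives only a limit and not a number, so neither the step to it from compound 3 nor the step to it from compound 1 can be read, because all three compounds stand at the same limit: the limit of > 100 ug/mL in this assay, at which 3 of the 4 values shown sit.

From the compounds shown here alone, what stays open is how far compound 1, compound 3 and compound 4 differ from one another in this assay, and whether isopropoxy in place of fluoro has the same size with acetyl or hydrogen on that oxygen.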